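This account rests on a few compounds, and the source may have more. Where it says the series, first, only, none or still open, it means among the compounds named here.

Compound 1 `C=C1C(=O)OC[C@H]1CCOC(=O)Nc1ccc(Cl)cc1` gives 390 nM in a functional assay on RAW264.7 cells (Mus musculus) for inhibition, with a stated time of 30 min; a higher number here means a weaker inhibitor, a lower number a stronger inhibitor.
Compound 2 `C=C1C(=O)OC[C@H]1CCOC(=O)Nc1ccc(Br)cc1` gives 350 nM in this assay.
Compound 3 `C=C1C(=O)OC[C@@H]1CCOC(=O)Nc1ccc(Br)cc1` gives 720 nM in this assay.

The three measured compounds share one core. Compound 2 and compound 1 differ only in chloro in place of bromo on an aromatic carbon, and this gave a 1.1-fold higher number from compound 2 to compound 1 (0.05 log units; within the scatter). Compound 2 and compound 3 are related by the two compounds have the same atoms and bonds and differ only in configuration as drawn: 1 of 1 stereo elements differ; a stereocentre at a saturated ring carbon is drawn S in compound 2 and R in compound 3; here a 2.1-fold higher number from compound 2 to compound 3 (0.31 log units; beyond the scatter) was seen, and the one thing that separates the pair is the fact that compounds 2 and 3 differ only in the configuration as drawn.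

Compound 4 `C=C1C(=O)OC[C@@H]1CCOC(=O)Nc1ccc(Cl)cc1` has not yet been measured in this assay. It differs from compound 3 by chloro in place of bromo on an aromatic carbon, the same change as that from compound 2 to compound 1, at the same place. Resting on a 1.1-fold higher number from compound 2 to compound 1 (0.05 log units; within the scatter), the expectation is that a 1.1-fold higher number from compound 3 to compound 4 (0.05 log units; within the scatter). Compound 4 is therefore estimated at 800 nM, expected to fall between 400 nM and 1600 nM.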

Compound 4, half-maximal inhibitory concentration: 1070 nM
Estimate against measurement, compound 4: 1.3-fold (0.13 log units) below, within the range that was stated.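

In this assay, chloro in place of bromo on an aromatic carbon gives a 1.5-fold higher number from compound 3 to compound 4 (0.17 log units; within the scatter), and the change carries across to the second core without a difference that can be told from the scatter: the same change on two cores in this assay, a 1.1-fold higher number (0.05 log units; within the scatter) from compound 2 to compound 1 and a 1.5-fold higher number (0.17 log units; within the scatter) from compound 3 to compound 4, 1.3-fold (0.13 log units) apart, within the scatter of two such steps
The other new step, a 2.7-fold higher number from compound 1 to compound 4 (0.44 log units; beyond the scatter), lies beyond the scatter, and only one thing separates that pair: the fact that compounds 1 and 4 differ only in the configuration as drawn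
This shows the halogen swap carrying over between two cores that are mirror-drawn at one stereocentre, but it does not show that it would carry over to a core altered in any other way.

The compounds shown leave open how fluoro, methoxy or an amine on the aromatic ring would read in this assay. They also leave open whether a longer chain on the shared core would preserve the difference between the two configurations.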